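This account rests on a few compounds, and the source may have more. Where it says the series, first, only, none or still open, it means among the compounds named here.

Compound 1 `N#Cc1c(Nc2ccccc2F)nc(SCc2cn(Cc3ccccc3Cl)nn2)nc1-c1ccccc1` — 8060 nM
Compound 2 `Cc1ccccc1Nc1nc(SCc2cn(Cc3ccccc3Cl)nn2)nc(-c2ccccc2)c1C#N` — 7950 nM
Compound 3 `Cc1ccc(Nc2nc(SCc3cn(Cc4ccc(F)cc4)nn3)nc(-c3ccccc3)c2C#N)cc1` — 51100 nM

In a functional assay on MCF7 cells (Homo sapiens) for inhibition, read by MTT assay, with a stated time of 72 h (on this read-out higher numbers stand for weaker inhibition and lower numbers for stronger inhibition), compound 3 stands highest of the three numbers, separated from both compound 1 and compound 2 by more than the usual scatter, while compound 1 and compound 2 lie within the scatter of each other, as the step of a 1.0-fold lower number from compound 1 to compound 2 (0.01 log units; within the scatter) shows. Compound 4 `Cc1ccc(Nc2nc(SCc3cn(Cc4ccccc4Cl)nn3)nc(-c3ccccc3)c2C#N)cc1` differs from compound 3 by 2-chlorophenyl in place of 4-fluorophenyl on a saturated chain carbon bound to an aromatic nitrogen. Going by the values given here, the single measured step concerns a different part of the molecule and does not bear on this change. Among the compounds with values here, compound 1 and compound 2, which both carry the entering 2-chlorobenzyl group, give lower numbers than compound 3, but each also differs from compound 3 elsewhere, so no measured pair isolates this change. The step of a 3.4-fold lower number from compound 3 to compound 4 (0.53 log units; beyond the scatter) is therefore expected to be downward but is uncertain. Compound 4 is estimated at 15000 nM, within a range from 5000 nM to 45000 nM.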

Compound 4, half-maximal inhibitory concentration: 9420 nM
The estimate for compound 4 lay 1.6-fold (0.20 log units) above the measured number, within the range that was stated.
By their numbers in this assay, from the lowest: compounds 2, 1 and 4 (each within the scatter of the next); then compound 3.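

In this assay, going by these compounds alone, the change from 4-fluorobenzyl to 2-chlorobenzyl, read alone for the first time, gives a 5.4-fold lower number from compound 3 to compound 4 (0.73 log units; beyond the scatter). With 2-chlorobenzyl in place, the group on the nitrogen on an aromatic ring leaves the number within the scatter, as a 1.2-fold higher number from compound 2 to compound 4 (0.07 log units; within the scatter) and a 1.2-fold higher number from compound 1 to compound 4 (0.07 log units; within the scatter) show. Nothing at hand explains the step at the benzyl position.

The compounds shown leave open how a plain benzyl or a 4-chlorobenzyl group would read at this place. The identity of the halogen and its place on the ring therefore remain unseparated.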